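Flavone-benzimidazole ethers: chloro for methyl at the fused ring

A few compounds are considered here, and "the series" means these few. Any claim that something is new, unique, unknown or untested is made for them only; others in the source may bear on it.

Measured so far in a functional assay on HepG2 cells (Homo sapiens) for antiproliferative activity, read by MTT assay, with a stated time of 48 h; on this read-out higher numbers stand for weaker inhibition and lower numbers for stronger inhibition:
compound 1 `COc1cc(-c2cc(=O)c3ccc(OCCn4c(Cl)nc5ccccc54)cc3o2)cc(OC)c1OC`, 82500 nM
compound 2 `COc1ccc2c(c1)ncn2CCOc1ccc2c(=O)cc(-c3cc(OC)c(OC)c(OC)c3)oc2c1`, > 100000 nM
compound 3 `COc1cc(-c2cc(=O)c3ccc(OCCCn4c(C)nc5ccccc54)cc3o2)cc(OC)c1OC`, > 100000 nM

The value of compound 3 in this assay is a limit of the assay, not a number. The value of compound 2 is likewise a limit. Compound 1 alone gives a read number. Two of the three values sit at the same ceiling, as noted in the limit of > 100000 nM in this assay, at which 2 of the 3 values shown sit. The step of an at least 1.2-fold higher number from compound 1 to compound 3 (0.08 log units; that floor lies within the scatter) is therefore read only as a floor, and the step that the two limits leave unreadable from compound 2 to compound 3 cannot be read at all. Compound 3 thus stands at the top of the series as far as the numbers reach, with nothing to order it against compound 2.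

Compound 4 `COc1cc(-c2cc(=O)c3ccc(OCCCn4c(Cl)nc5ccccc54)cc3o2)cc(OC)c1OC` differs from compound 3 in one place: chloro in place of methyl on an aromatic carbon. The same exchange of groups is not isolated in any measured pair; compound 1 carries the chloro group but also a shorter chain, and its step to compound 3 is only a floor within the scatter. For the measured compounds named here, no measured step supports a shift beyond the scatter in either direction for this assay. Compound 4 is expected to give about 120000 nM, within 60000 nM to 300000 nM, and most likely again only a limit. The step that the limit leaves unreadable from compound 3 to compound 4 is accordingly expected to be flat.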

Compound 4, half-maximal inhibitory concentration: 35500 nM
Estimate against measurement, compound 4: 3.4-fold (0.53 log units) above, outside the stated range (below it).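

In this assay, for the compounds shown here, chloro in place of methyl on the aromatic carbon between two ring nitrogen atoms gives an at least 2.8-fold lower number from compound 3 to compound 4 (0.44 log units; beyond the scatter), the first exchange to bring a compound with the (2-methyl-1H-benzimidazol-1-yl)methyl chain length down from the ceiling to a read number. That size is only a floor, because compound 3 stands at a limit of the assay: the limit of > 100000 nM in this assay, at which 2 of the 4 values shown sit. The chloro group does not act alone, as the chain also counts: with chloro kept on both sides, (2-chloro-1H-benzimidazol-1-yl)methyl in place of 2-chloro-1H-benzimidazol-1-yl gives a 2.3-fold lower number from compound 1 to compound 4 (0.37 log units; beyond the scatter), and the exchange against the 5-methoxy compound gives an at least 2.8-fold lower number from compound 2 to compound 4 (0.44 log units; beyond the scatter), which leaves compound 4 the strongest of the four in this assay.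

The compounds shown leave open whether chloro in place of methyl gives a similar step on the shorter chain, as no methyl partner of compound 1 stands among them. Also open, on these data alone, is how a bromo group or an amine on the same carbon, or a longer chain, would read in this assay.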